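The compounds below may be only part of what the source reports. "The series", "measured", "known", "first", "only" and "open" are said of these compounds alone.

Measured in an ADME assay on microsomes from liver (Homo sapiens) for metabolic stability, read by HPLC, using NADPH, with stated times of 10 min and 60 min; a lower number here means that less of the compound is left, a higher number that more of the compound is left:
- Compound 1 `Cc1ccc(NC(=O)CCCn2cc(-c3ccc(C(F)(F)F)cc3)nn2)cc1`: 84%
- Compound 2 `COC(=O)c1ccc(-c2cn(CCCC(=O)Nc3ccc(-c4ccccc4)cc3)nn2)cc1`: 87%

In this assay compound 2 gives 87%, which is within the scatter of compound 1 at 84%. Compound 3 `O=C(CCCn1cc(-c2ccc(C(F)(F)F)cc2)nn1)Nc1ccc(-c2ccccc2)cc1` carries trifluoromethyl in place of methoxycarbonyl on an aromatic carbon, para to a large group (trifluoromethyl in place of methoxycarbonyl on an aromatic carbon). Among the compounds with values here, no measured pair isolates this change. However, compound 1 also carries 4-(trifluoromethyl)phenyl and gives 84%, so no change beyond the scatter is expected. The expected step of a number 3 percentage points lower from compound 2 to compound 3 (within the scatter) is small. For compound 3 the estimated value is 84%, with an expected range of 72% to 94%.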

Compound 3, percent of the compound remaining: 60%
Beside the measured number, compound 3's estimate is 24 percentage points above it; measured number outside the range, below it.
By their numbers in this assay, from the lowest: compound 3; then compounds 1 and 2 (each within the scatter of the next).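

In this assay, trifluoromethyl in place of methoxycarbonyl gives a number 27 percentage points lower from compound 2 to compound 3 (beyond the scatter) and phenyl in place of methyl gives a number 24 percentage points lower from compound 1 to compound 3 (beyond the scatter), so this position is not indifferent to the change. Neither 4-(trifluoromethyl)phenyl nor the phenyl on the anilide side goes with a low number by itself, since compound 1 and compound 2 each carry one of them; only compound 3 carries both. Nothing available gives a reason for these steps. The compounds shown leave open whether a nitrile or a carboxylic acid in place of trifluoromethyl would behave like methoxycarbonyl here.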